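Isopentyl carbamate variant of a bis-trimethoxybenzoyl piperazine

This account rests on a few compounds, and the source may have more. Where it says the series, first, only, none or still open, it means among the compounds named here.

Measured so far:
compound 1, `CCCCNC(=O)OCC1CN(C(=O)c2cc(OC)c(OC)c(OC)c2)CCN1C(=O)c1cc(OC)c(OC)c(OC)c1`: 240 nM
compound 2, `COc1cc(C(=O)N2CCN(C(=O)c3cc(OC)c(OC)c(OC)c3)C(COC(=O)NC(C)C(C)(C)C)C2)cc(OC)c1OC`: 170 nM

Both compounds share a core carrying two trimethoxybenzoyl groups and a carbamate whose nitrogen bears an alkyl chain. In a functional assay (Oryctolagus cuniculus) for inhibition of platelet-activating factor receptor (Cavia porcellus) (on this read-out lower numbers stand for stronger inhibition and higher numbers for weaker inhibition), compound 1 gives 240 nM and compound 2 gives 170 nM. Among the measured compounds shown here, the only step so far, a 1.4-fold lower number from compound 1 to compound 2 (0.15 log units; within the scatter), came with 1,2,2-trimethylpropyl in place of butyl on an amide-type nitrogen. Since that step lies within the scatter, compound 2 cannot be set apart from compound 1 on these numbers; it simply stands beside it.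

Compound 3, `COc1cc(C(=O)N2CCN(C(=O)c3cc(OC)c(OC)c(OC)c3)C(COC(=O)NCCC(C)C)C2)cc(OC)c1OC`, differs from compound 2 by isopentyl in place of 1,2,2-trimethylpropyl on an amide-type nitrogen. For the measured compounds named here, only the step from compound 1 to compound 2 bears on this: it also exchanged one alkyl chain for another on the same amide-type nitrogen and stayed within the scatter. Isopentyl is a chain of a size between butyl and 1,2,2-trimethylpropyl, so no step beyond the scatter is expected in this assay either way. Compound 3 is therefore estimated at 200 nM, within 100 nM to 400 nM, meaning an expected step of a 1.2-fold higher number from compound 2 to compound 3 (0.07 log units; within the scatter).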

Compound 3, half-maximal inhibitory concentration: 140 nM
The estimate for compound 3 lay 1.4-fold (0.15 log units) above the measured number, and the stated range covers the measured number.
By their numbers in this assay, from the lowest: compounds 3, 2 and 1 (each within the scatter of the next).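

In this assay the exchange of 1,2,2-trimethylpropyl for isopentyl on the amide-type nitrogen gives a 1.2-fold lower number from compound 2 to compound 3 (0.08 log units; within the scatter) and counts as no real difference, while the butyl-to-isopentyl exchange, which adds one methyl to the chain, gives a 1.7-fold lower number from compound 1 to compound 3 (0.23 log units; within the scatter) and so counts as none either. Among the compounds shown here, the earlier pair offered only one exchange of alkyl groups, whereas this position now carries three: butyl, isopentyl and 1,2,2-trimethylpropyl, and every step among them stays within the normal variation between repeat measurements, so this read-out does not tell these three groups apart. No separate measurement is available that could explain this result.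

From the compounds shown here alone, all three groups are saturated carbon chains without a ring, so it remains open whether a much longer chain such as decyl, a phenyl ring, an amine or a carboxylic acid at this nitrogen would move the number beyond the scatter. Going by these compounds, it is equally open whether a group of the size of methyl, far shorter than butyl, would still stand with these three.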